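Cyano for Fluoro on the Benzyl Group: Cytotoxicity Outlook

This account rests on a few compounds, and the source may have more. Where it says the series, first, only, none or still open, it means among the compounds named here.

Measured so far in an ADME assay on HepG2 cells (Homo sapiens) for cytotoxicity, read by luminescence, CellTiter-Glo and ATP content, with a stated time of 72 h; on this read-out lower numbers stand for an effect already at smaller amounts and higher numbers for an effect only at larger amounts of compound:
compound 1, `CCC(CC)c1ccc2c(NCCCNCc3cccc(OC)c3O)ccnc2c1`, gives 410 nM;
compound 2, `COc1cccc(CNCCCNc2ccnc3cc(Oc4ccccc4)ccc23)c1O`, gives 6800 nM;
compound 3, `COc1cccc(CNCCCNc2ccnc3cc(Cc4ccc(F)cc4)ccc23)c1O`, gives 4780 nM.

Among these three numbers compound 3 stands second highest. Its nearest neighbour is compound 2, and that pair is not separated: a 1.4-fold lower number from compound 2 to compound 3 (0.15 log units; within the scatter). Compound 1 lies far off from it: a 12-fold higher number from compound 1 to compound 3 (1.07 log units; beyond the scatter).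

Compound 4, `COc1cccc(CNCCCNc2ccnc3cc(Cc4ccc(C#N)cc4)ccc23)c1O`, differs from compound 3 in one place: cyano in place of fluoro on an aromatic carbon. Within the data shown here, no measured step touches this part of the molecule. The steps of a 17-fold higher number from compound 1 to compound 2 (1.22 log units; beyond the scatter) and a 12-fold higher number from compound 1 to compound 3 (1.07 log units; beyond the scatter) exchange the whole group on the shared core for another, and the step of a 1.4-fold lower number from compound 2 to compound 3 (0.15 log units; within the scatter) compares phenoxy with 4-fluorobenzyl as a whole. Compound 2 and compound 3 sit within the scatter of each other, so an exchange of one small substituent within the 4-fluorobenzyl group is expected to move this assay little. The expected step of a 1.0-fold higher number from compound 3 to compound 4 (0.02 log units; within the scatter) is estimated to stay within the scatter. Compound 4 is therefore estimated at 5000 nM, with a range from 2000 nM to 13000 nM.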

Compound 4, half-maximal effective concentration: 7150 nM
Estimate against measurement, compound 4: 1.4-fold (0.16 log units) below; the range from low to high includes it.
By their numbers in this assay, from the lowest: compound 1; then compounds 3, 2 and 4 (each within the scatter of the next).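

In this assay, the exchange at this place on the aromatic ring of the benzyl group gives a 1.5-fold higher number from compound 3 to compound 4 (0.17 log units; within the scatter), so cyano and fluoro are not told apart here, even though cyano brings one hydrogen-bond acceptor and fluoro none. The 4-cyanobenzyl group also stays level with phenoxy, at a 1.1-fold higher number from compound 2 to compound 4 (0.02 log units; within the scatter), while the distance from the pentan-3-yl group stays wide, at a 17-fold higher number from compound 1 to compound 4 (1.24 log units; beyond the scatter), so compound 1 remains alone among the four. Nothing available explains why cyano and fluoro read alike here.

Open, as far as these compounds go, is whether an amine or a carboxylic acid in this same place would also stay within the scatter of compound 3. Also open, from the compounds shown here alone, is whether a shorter chain such as ethyl would sit near compound 1 or near the other three.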